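The source may report more compounds than this note shows. Statements on the series, on what has been measured and on what is new or still open speak of the compounds shown alone.

Compound 1 `COc1ccc(N(C)c2nc(C)nc3ccccc23)cc1C(=O)OCC[Se]C#N`: 353 nM
Compound 2 `COc1ccc(N(C)c2nc(C)nc3ccccc23)cc1OCCCCCC[Se]C#N`: 5520 nM
Compound 3 `COc1ccc(N(C)c2nc(C)nc3ccccc23)cc1C(=O)OCCCC[Se]C#N`: 155 nM

In a functional assay on A549 cells (Homo sapiens) for inhibition, read by MTT assay, with a stated time of 48 h (on this read-out lower numbers stand for stronger inhibition and higher numbers for weaker inhibition), compound 3 gives 155 nM, the lowest number of the three. Compound 4 `COc1ccc(N(C)c2nc(C)nc3ccccc23)cc1OCCCC[Se]C#N` has not yet been measured. Its structure departs from compound 3 in one place: a group of 8 heavy atoms (5 carbon, 1 nitrogen, 1 oxygen, 1 selenium; no ring) in place of a group of 10 heavy atoms (6 carbon, 1 nitrogen, 2 oxygen, 1 selenium; no ring), on an aromatic carbon. The site is an aromatic carbon of a six-membered aromatic ring of carbon only, ortho to a methoxy group.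

Compound 4 shares with compound 2 the absence of a carbonyl in this group, so two large steps bear on it: a 16-fold higher number from compound 1 to compound 2 (1.19 log units; beyond the scatter) and a 36-fold lower number from compound 2 to compound 3 (1.55 log units; beyond the scatter). Neither isolates the change made here, since the groups in those pairs differ in more than the carbonyl. Chain changes alone may also matter, as a 2.3-fold lower number from compound 1 to compound 3 (0.36 log units; beyond the scatter) is modest but beyond the scatter. Going by the values given here, with only three compounds, this pattern is thin, so a large rise is expected, probably short of the full gap to compound 2. The expected change is a 9.7-fold higher number from compound 3 to compound 4 (0.99 log units; beyond the scatter). For compound 4 the estimated value is 1500 nM, with an expected range of 350 nM to 6000 nM.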

Compound 4, half-maximal inhibitory concentration: 1200 nM
The estimate for compound 4 lay 1.3-fold (0.10 log units) above the measured number; measured number inside the range.
By their numbers in this assay, from the lowest: compound 3; then compound 1; then compound 4; then compound 2.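

a 7.7-fold higher number from compound 3 to compound 4 (0.89 log units; beyond the scatter) is the first step that removes the carbonyl from the linkage on this aromatic carbon while leaving the chain unchanged, so the ester beats the ether here without a change in chain to muddy the comparison. The ester with the shorter chain also stays on the low side of this ether, with a 3.4-fold higher number from compound 1 to compound 4 (0.53 log units; beyond the scatter). Chain length, meanwhile, does not act alike on the two linkages: shortening the ether chain gives a 4.6-fold lower number from compound 2 to compound 4 (0.66 log units; beyond the scatter), whereas lengthening the ester chain lowered the number, so the same chain change runs in opposite directions: the same change on two cores in this assay, a 2.3-fold lower number (0.36 log units; beyond the scatter) from compound 1 to compound 3 and a 4.6-fold higher number (0.66 log units; beyond the scatter) from compound 4 to compound 2, 10-fold (1.02 log units) apart, beyond the scatter of two such steps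

On these data alone, whether an amide in place of the ester would hold the low number remains open. So does whether a longer chain on the ester would lower it further, and the compounds shown do not tell why the carbonyl matters.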